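A few compounds are considered here, and "the series" means these few. Any claim that something is new, unique, unknown or untested is made for them only; others in the source may bear on it.

Compound 1 `CCCN1CCC(CNCc2cn(-c3ccc([N+](=O)[O-])cc3)nc2-c2ccc(C(F)(F)F)cc2)CC1` gives 2300 nM in an ADME assay on Huh-7 cells (Homo sapiens) for cytotoxicity; a higher number here means that more compound is tolerated, a lower number that less compound is tolerated. Compound 2 `CCCN1CCC(CNCc2cn(-c3ccc(C(F)(F)F)cc3)nc2-c2ccc(C(F)(F)F)cc2)CC1` differs from it in one place: trifluoromethyl in place of nitro on an aromatic carbon. In this assay compound 2 gives 1200 nM, which amounts to a 1.9-fold lower number from compound 1 to compound 2 (0.28 log units; within the scatter). Compound 3 `CN1CCN(CCNCc2cn(-c3ccc([N+](=O)[O-])cc3)nc2-c2ccc(Cl)cc2)CC1` is built on another core; how its core differs from that of compound 1 is not broken down here. In this assay compound 3 gives 5000 nM, the highest of the three numbers; its gap to compound 1 and to compound 2 lies beyond the scatter in each case, so compound 3 is the best tolerated of the measured set.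

Compound 4 `CN1CCN(CCNCc2cn(-c3ccc(C(F)(F)F)cc3)nc2-c2ccc(Cl)cc2)CC1` remains to be measured. It differs from compound 3 in one place: trifluoromethyl in place of nitro on an aromatic carbon. This is the same change as between compound 1 and compound 2, and the place is described in the same words, so the two changes are the same. Among the measured compounds shown here, only one measured instance of it exists, and that instance stayed within the scatter.

For the measured compounds named here, for compound 4 in this assay a step of a 1.8-fold lower number from compound 3 to compound 4 (0.25 log units; within the scatter) is expected, resting on the single precedent, because the identical change gave a 1.9-fold lower number from compound 1 to compound 2 (0.28 log units; within the scatter). Compound 4 is therefore expected near 2800 nM, with a likely range from 1400 nM to 5600 nM.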

Compound 4, half-maximal cytotoxic concentration: 3000 nM
Estimate against measurement, compound 4: 1.1-fold (0.03 log units) below; measured number inside the range.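

In this assay, trifluoromethyl in place of nitro on an aromatic carbon gives a 1.7-fold lower number from compound 3 to compound 4 (0.22 log units; within the scatter), on a different core from the earlier instance of this change. The two instances agree: the same change on two cores in this assay, a 1.9-fold lower number (0.28 log units; within the scatter) from compound 1 to compound 2 and a 1.7-fold lower number (0.22 log units; within the scatter) from compound 3 to compound 4, 1.2-fold (0.06 log units) apart, within the scatter of two such steps

Within this series, the change therefore carries from the core of compound 1 to the core of compound 3 with a matching step, although two cores are a narrow basis, neither step lies beyond the scatter, and no separation between the two groups on tolerance is established on either core.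

Still open, from the compounds shown here alone, is what other groups do on the same aromatic carbon, para to a large group, such as a nitrile, a carboxylic acid or an amine in place of nitro or trifluoromethyl. Also open, going by these compounds, is whether the same agreement would hold on a third core, or for this change outside this assay.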